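The source may hold more compounds than are shown below. What is called first, only, known or untested is meant among the compounds shown, and "the series" means these compounds.

Measured compounds:
- compound 1, `O=C1NCCN1c1ccc(S(=O)(=O)Nc2ccc(F)c(F)c2)cc1`, 220 nM
- compound 2, `O=C1NCCN1c1ccc(S(=O)(=O)Nc2cccc(Br)c2)cc1`, 59 nM
- compound 3, `Cc1cccc(NS(=O)(=O)c2ccc(N3CCNC3=O)cc2)c1C`, 110 nM

In a functional assay on M21 cells (Homo sapiens) for antiproliferative activity, read by sulforhodamine B assay, with a stated time of 48 h (on this read-out lower numbers stand for stronger inhibition and higher numbers for weaker inhibition), compound 3 stands second highest of the three numbers; its nearest neighbour is compound 2, a 1.9-fold higher number from compound 2 to compound 3 (0.27 log units; within the scatter), and its furthest is compound 1, a 2.0-fold lower number from compound 1 to compound 3 (0.30 log units; within the scatter). Both of those steps lie within the scatter, so compound 3 cannot be set apart from either.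

Compound 4, `COc1cccc(NS(=O)(=O)c2ccc(N3CCNC3=O)cc2)c1`, differs from compound 3 in one place: 3-methoxyphenyl in place of 2,3-dimethylphenyl on a sulfonamide nitrogen. All three measured steps change the aryl group on the sulfonamide nitrogen while the rest of the molecule is kept, so each bears on this change. Only one of them, a 3.7-fold lower number from compound 1 to compound 2 (0.57 log units; beyond the scatter), went beyond the scatter; the other two, a 2.0-fold lower number from compound 1 to compound 3 (0.30 log units; within the scatter) and a 1.9-fold higher number from compound 2 to compound 3 (0.27 log units; within the scatter), stayed within it. Swapping one substituted phenyl for another at this position has therefore moved the number in this assay by modest amounts at most, with no clear direction.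

On that basis compound 4 is expected to stay close to compound 3, with a step of no change at the digits printed from compound 3 to compound 4 (within the scatter) that is not expected to exceed the scatter. The estimate for compound 4 in this assay is 110 nM, within a range from 40 nM to 300 nM.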

Compound 4, half-maximal inhibitory concentration: 65 nM
Beside the measured number, compound 4's estimate is 1.7-fold (0.23 log units) above it; measured number inside the range.
By their numbers in this assay, from the lowest: compounds 2, 4, 3 and 1 (each within the scatter of the next, the first and the last beyond it).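

In this assay, 3-methoxyphenyl in place of 2,3-dimethylphenyl gives a 1.7-fold lower number from compound 3 to compound 4 (0.23 log units; within the scatter), and methoxy in place of bromo on an aromatic carbon gives a 1.1-fold higher number from compound 2 to compound 4 (0.04 log units; within the scatter), so a group bringing a hydrogen-bond acceptor to this position cannot be set apart from either group it replaces. The step of a 3.4-fold lower number from compound 1 to compound 4 (0.53 log units; beyond the scatter) is the second beyond the scatter, and, like a 3.7-fold lower number from compound 1 to compound 2 (0.57 log units; beyond the scatter), it starts from the 3,4-difluorophenyl group, which suggests that compound 1 stands apart from the compounds carrying 3-bromophenyl and 3-methoxyphenyl, though compound 3 goes against any wider reading with a 2.0-fold lower number from compound 1 to compound 3 (0.30 log units; within the scatter). Nothing available explains these differences or the lack of them.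

The compounds shown leave open whether a phenyl ring bearing an amine or a carboxylic acid, or a longer chain in place of methoxy, would stay within this same range of numbers. They also leave open what happens when something other than a substituted phenyl sits on the sulfonamide nitrogen, or when the shared core itself is changed.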